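Compound 2 to compound 4: a new group on the ring nitrogen

The compounds below may be only part of what the source reports. "The series", "measured", "known", "first", "only" and "open" are said of these compounds alone.

In a functional assay on A549 cells (Homo sapiens) for inhibition, read by sulforhodamine B assay (a higher number here means a weaker inhibitor, a lower number a stronger inhibitor), compound 1 `COC(=O)CC/C(C)=C/Cc1c(OC)c(C)c2c(c1OCC#CCN1CCN(c3ccc(C#N)cc3)CC1)C(=O)OC2` gives > 50000 nM, which is a limit. Compound 2 `COC(=O)CC/C(C)=C/Cc1c(OC)c(C)c2c(c1OCC#CCN1CCN(Cc3ccc(Cl)cc3)CC1)C(=O)OC2` gives > 50000 nM, also a limit. Going by the values given here, compound 3 `COC(=O)CC/C(C)=C/Cc1c(OC)c(C)c2c(c1OCC#CCN1CCN(C(c3ccccc3)c3ccc(Cl)cc3)CC1)C(=O)OC2` gives 29100 nM, the only true number so far. Compound 2 therefore sits at the limit of > 50000 nM in this assay, at which 2 of the 3 values shown sit, with no measured position of its own.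

Compound 4 `COC(=O)CC/C(C)=C/Cc1c(OC)c(C)c2c(c1OCC#CCN1CCN(C(=O)C3COc4ccccc4O3)CC1)C(=O)OC2` carries (2,3-dihydro-1,4-benzodioxin-2-yl)carbonyl in place of 4-chlorobenzyl on an amine nitrogen in a ring, with (2,3-dihydro-1,4-benzodioxin-2-yl)carbonyl in place of 4-chlorobenzyl on an amine nitrogen in a ring. a step that the two limits leave unreadable from compound 1 to compound 2 gives no size. an at least 1.7-fold lower number from compound 2 to compound 3 (0.23 log units; that floor lies within the scatter) is only a floor and involves a different group. No change beyond the scatter is expected in this assay, and the expected step is a number no higher from compound 2 to compound 4 (the limit leaves the size open). Compound 4 is estimated at 50000 nM, within 20000 nM to 100000 nM.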

Compound 4, half-maximal inhibitory concentration: > 50000 nM
Compound 4: no number, only a limit; the forecaster's own chance of this, stated with the estimate: 75%; the middle value sits exactly at the limit.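

Going by these compounds alone, compound 1, compound 2 and compound 4 all stand at a limit in this assay, so no step among them can be read. The compounds shown leave open how these three rank against one another.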